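Lengthening the alkynyl chain on a nucleoside

A few compounds are considered here, and "the series" means these few. Any claim that something is new, unique, unknown or untested is made for them only; others in the source may bear on it.

Among the three compounds measured in an ADME assay on MRC5 cells (Homo sapiens) for cytotoxicity, read by MTT assay (on this read-out lower numbers stand for higher toxicity in this test and higher numbers for lower toxicity in this test), compound 1 `CCCCC#Cc1cn([C@@H]2O[C@H](CO)[C@@H](O)[C@H]2O)c(=O)[nH]c1=O` stands lowest: in this assay compound 1 gives 11600 nM. Compound 2 `CCCCCCC#Cc1c[nH]c(=O)[nH]c1=O` gives 94900 nM and compound 3 `O=c1[nH]cc(C#CC2CC2)c(=O)[nH]1` gives 101000 nM; both lie well apart from compound 1, while the two of them sit within the scatter of each other. Compound 4 `CCCCCCC#Cc1cn([C@@H]2O[C@H](CO)[C@@H](O)[C@H]2O)c(=O)[nH]c1=O` is not yet measured. It differs from compound 1 by ethyl in place of hydrogen on a saturated chain carbon, four bonds along the chain from a triple-bonded carbon. For the measured compounds named here, no measured pair shows such a chain extension on the shared core of compound 1, so a step of any size beyond the scatter is not expected in either direction. Compound 4 is therefore estimated at 9500 nM, within 3500 nM to 28000 nM, a step from compound 1 to compound 4 of a 1.2-fold lower number from compound 1 to compound 4 (0.09 log units; within the scatter).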

Compound 4, half-maximal cytotoxic concentration: 15700 nM
The estimate for compound 4 lay 1.7-fold (0.22 log units) below the measured number; the measured number falls inside the stated range.
By their numbers in this assay, from the lowest: compounds 1 and 4 (each within the scatter of the next); then compounds 2 and 3 (each within the scatter of the next).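

In this assay, ethyl in place of hydrogen on a saturated chain carbon, four bonds along the chain from a triple-bonded carbon, gives a 1.4-fold higher number from compound 1 to compound 4 (0.13 log units; within the scatter) on the shared core. For the compounds shown here, this is the first step read at this position, and it shows that this chain extension does not move the number beyond the scatter. Nothing measured here offers an explanation for this result.

From the compounds shown here alone, what a longer chain, or a chain carrying an amine or a carboxylic acid, would do at this position remains open.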